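The source may hold more compounds than are shown below. What is called first, only, known or untested is meant among the compounds shown, and "the series" means these compounds.

Compound 3 `Cc1cc(C#N)cc(C)c1Oc1nc(Nc2ccc(C#N)cc2)ncc1/C=C/C(=O)NCC1CCN(S(C)(=O)=O)CC1` is one of three members of this series carrying the shared core with an amide at the end of the alkenyl chain, the amide nitrogen bearing different substituents. In an ADME assay on TZM cells (Homo sapiens) for cytotoxicity, with a stated time of 1 days (a lower number here means that less compound is tolerated, a higher number that more compound is tolerated), compound 3 gives only a limit, > 171 nM. Compound 1 `Cc1cc(C#N)cc(C)c1Oc1nc(Nc2ccc(C#N)cc2)ncc1/C=C/C(N)=O`, with hydrogen on that amide nitrogen, also gives only a limit in this assay, > 243 nM. Compound 2 `C#CCNC(=O)/C=C/c1cnc(Nc2ccc(C#N)cc2)nc1Oc1c(C)cc(C#N)cc1C`, with propargyl there, gives a limit as well, > 222 nM. All three values therefore sit at their own limits, (the limit of > 171 nM in this assay, at which 1 of the 3 values shown sits), the limit of > 222 nM in this assay, at which 1 of the 3 values shown sits, and (the limit of > 243 nM in this assay, at which 1 of the 3 values shown sits), so every measured step stays unreadable: a step that the two limits leave unreadable from compound 1 to compound 2, a step that the two limits leave unreadable from compound 1 to compound 3 and a step that the two limits leave unreadable from compound 2 to compound 3.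

Compound 4 `Cc1cc(C#N)cc(C)c1Oc1nc(Nc2ccc(C#N)cc2)ncc1/C=C/C(=O)NC1CCN(S(C)(=O)=O)C1` differs from compound 3 in one place: 1-(methylsulfonyl)pyrrolidin-3-yl in place of (1-(methylsulfonyl)piperidin-4-yl)methyl on an amide-type nitrogen. Within the data shown here, no measured step bears readably on this change; what the series shows is that substituents on the amide nitrogen of three different sizes have all left the readout at a limit. A step from compound 3 to compound 4 of about a step that the limit leaves unreadable from compound 3 to compound 4 is expected, most likely again reported as a limit. For compound 4 the expected value in this assay is 250 nM, within a range from 150 nM to 600 nM.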

Compound 4, half-maximal cytotoxic concentration: > 179 nM
Compound 4: a limit, no number; the forecaster's own chance of this, stated with the estimate: 85%; the middle value lies beyond the limit too.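

In this assay compound 4 gives only a limit, > 179 nM, so its steps from compound 1, compound 2 and compound 3 cannot be read. The compounds shown leave open whether the different substituents on the amide nitrogen change the half-maximal cytotoxic concentration at all.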